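The compounds below may be only part of what the source reports. "The series", "measured", "known", "first", "only" and "open" are said of these compounds alone.

Compound 1, `CCS(=O)(=O)Nc1cc(-c2ccc3ncnc(Nc4cccc(F)c4)c3c2)cnc1OC`, gives 3940 nM in a functional assay on HCT-116 cells (Homo sapiens) for cytotoxicity, read by sulforhodamine B assay, with a stated time of 72 h; a lower number here means a stronger inhibitor, a higher number a weaker inhibitor.
Compound 2, `CCS(=O)(=O)Nc1cc(-c2ccc3ncnc(Nc4ccc(OC(F)(F)F)cc4)c3c2)cnc1OC`, gives 16600 nM in this assay.
Compound 3, `CCS(=O)(=O)Nc1cc(-c2ccc3ncnc(Nc4ccc(F)c(C(=O)OC)c4)c3c2)cnc1OC`, gives 2360 nM in this assay.

Among these three, compound 2 has the highest number, so it is the weakest inhibitor: the step of a 4.2-fold higher number from compound 1 to compound 2 (0.62 log units; beyond the scatter) and the step of a 7.0-fold lower number from compound 2 to compound 3 (0.85 log units; beyond the scatter) both lie beyond the scatter, while the step of a 1.7-fold lower number from compound 1 to compound 3 (0.22 log units; within the scatter) does not.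

Compound 4, `CCS(=O)(=O)Nc1cc(-c2ccc3ncnc(Nc4ccc(OC)nc4)c3c2)cnc1OC`, is not yet measured in this assay. It differs from compound 2 in one place: 6-methoxypyridin-3-yl in place of 4-(trifluoromethoxy)phenyl on a nitrogen on an aromatic ring.

Going by the values given here, two measured steps bear on this change, since each swaps the group on that same nitrogen. Replacing 4-(trifluoromethoxy)phenyl gave a lower number in both cases, a 4.2-fold higher number from compound 1 to compound 2 (0.62 log units; beyond the scatter) read in reverse and a 7.0-fold lower number from compound 2 to compound 3 (0.85 log units; beyond the scatter). Nothing is known about 6-methoxypyridin-3-yl itself, so the size of the step is uncertain, but a modest move towards a lower number is expected, roughly a 3.7-fold lower number from compound 2 to compound 4 (0.57 log units; beyond the scatter). For compound 4 the expected value in this assay is 4500 nM, within a range of 1500 nM to 13000 nM.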

Compound 4, half-maximal inhibitory concentration: 6910 nM
The estimate for compound 4 lay 1.5-fold (0.19 log units) below the measured number; low and high end bracket the measured number.
By their numbers in this assay, from the lowest: compounds 3, 1 and 4 (each within the scatter of the next, the first and the last beyond it); then compound 2.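

In this assay, a ring holding a hetero atom is accepted on this nitrogen: 6-methoxypyridin-3-yl still improves on 4-(trifluoromethoxy)phenyl (a 2.4-fold lower number from compound 2 to compound 4 (0.38 log units; beyond the scatter)), so all three other groups shown now give a lower number than that group. The new group does not match the 4-fluoro-3-(methoxycarbonyl)phenyl group (a 2.9-fold higher number from compound 3 to compound 4 (0.47 log units; beyond the scatter)), and it cannot be separated from 3-fluorophenyl (a 1.8-fold higher number from compound 1 to compound 4 (0.24 log units; within the scatter)). No measurement is available that explains these differences.

Because the ring and its substituent change together in this step, the compounds shown cannot say which of the two accounts for the shift, and a 4-methoxyphenyl group on the same nitrogen would separate them. Also open, on these data alone, is how a carboxylic acid or an amine on this ring would fare.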